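The compounds below may be only part of what the source reports. "The series", "measured", "known", "first", "only" and "open" are said of these compounds alone.

For the measured compounds named here, compound 2 `CCCSc1nc(N/N=C(\C)c2ccccc2O)c2nnn(Cc3cccc(Cl)c3)c2n1` stands on the lowest of the three numbers so far measured in a functional assay on MGC-803 cells (Homo sapiens) for antiproliferative activity, read by MTT assay, with a stated time of 72 h (on this read-out lower numbers stand for stronger inhibition and higher numbers for weaker inhibition), where compound 2 gives 6500 nM. Its neighbours on this scale are close: compound 3 `CCCSc1nc(N/N=C/c2ccc([N+](=O)[O-])cc2)c2nnn(Cc3ccccc3)c2n1` gives 10100 nM in this assay, and compound 1 `CCCSc1nc(N/N=C/c2ccc(N(C)C)cc2)c2nnn(Cc3ccccc3)c2n1` gives 13100 nM, and both of these lie within the scatter of compound 2, so no order can be claimed among the three.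

The step under consideration leads to compound 4 `CCCSc1nc(N/N=C(\C)c2ccccc2O)c2nnn(Cc3ccccc3)c2n1`, which differs from compound 2 in one place: hydrogen in place of chloro on an aromatic carbon.

Going by the values given here, the only measured step between compounds differing in one place concerns the hydrazone aryl group rather than the benzyl group, and it reads a 1.3-fold lower number from compound 1 to compound 3 (0.11 log units; within the scatter). Among the compounds with values here, no measured pair shows what removing a chloro from the benzyl group does in this assay, so there is no direct precedent. With every difference among the measured compounds falling within the scatter, and the change in compound 4 being the loss of a single chlorine, no step beyond the scatter is expected in either direction. The number for compound 4 in this assay is therefore estimated at 8500 nM, with a range from 3500 nM to 20000 nM, which means an expected step of a 1.3-fold higher number from compound 2 to compound 4 (0.12 log units; within the scatter).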

Compound 4, half-maximal inhibitory concentration: 2310 nM
Estimate against measurement, compound 4: 3.7-fold (0.57 log units) above; measured number below the stated range.
By their numbers in this assay, from the lowest: compound 4; then compounds 2, 3 and 1 (each within the scatter of the next).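

In this assay, for the compounds shown here, the change from 3-chlorobenzyl to benzyl gives a 2.8-fold lower number from compound 2 to compound 4 (0.45 log units; beyond the scatter) and is the first step to lie beyond the scatter. Going by these compounds alone, the only earlier step concerned the aromatic group on the hydrazone and stayed within the scatter, so this pair is the first to show that the aromatic carbon carrying the chloro, meta to a large group, can shift the read-out, and that the compound with hydrogen there gives the lower number of the two. The finding rests on this one pair, and nothing measured on these compounds accounts for the size or direction of the step.

On these data alone, it remains open whether the same replacement of chloro by hydrogen would give a similar step with the other hydrazone parts, such as those carried by compound 1 and compound 3, since the step is known only with the hydrazone shared by compound 2 and compound 4. How a fluoro, a methoxy or an amine on that same aromatic carbon would compare with hydrogen and chloro in this assay also remains an open question.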